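Shifting the Methyl on the Pyridazine Ring

The compounds below may be only part of what the source reports. "The series", "measured", "known", "first", "only" and "open" are said of these compounds alone.

Measured compounds:
compound 1 `Cc1ccnnc1N1CCN(C(=O)Nc2ccc(C(C)(C)C)cc2)[C@H](C)C1`: 15.2 nM
compound 2 `Cc1cc(Cl)nnc1N1CCN(C(=O)Nc2ccc(C(C)(C)C)cc2)[C@H](C)C1`: 67.5 nM

Within the data shown here, in an assay on HEK293 cells for inhibition of transient receptor potential cation channel subfamily V member 1 (Homo sapiens), read by FLIPR, at pH 5.5 (on this read-out higher numbers stand for weaker inhibition and lower numbers for stronger inhibition), compound 2 gives 67.5 nM, the higher of the two numbers; compound 1 gives 15.2 nM, and the only measured step is a 4.4-fold higher number from compound 1 to compound 2 (0.65 log units; beyond the scatter). Compound 3 `Cc1cc(N2CCN(C(=O)Nc3ccc(C(C)(C)C)cc3)[C@H](C)C2)nnc1Cl` differs from compound 2 by 6-chloro-5-methylpyridazin-3-yl in place of 6-chloro-4-methylpyridazin-3-yl on an amine nitrogen in a ring. Among the measured compounds shown here, no measured step bears on this change: the step of a 4.4-fold higher number from compound 1 to compound 2 (0.65 log units; beyond the scatter) concerns the chloro and says nothing about where the methyl sits. Compound 3 is therefore expected to show a 1.0-fold higher number from compound 2 to compound 3 (0.02 log units; within the scatter), a change within the scatter, and is estimated at 70 nM with a range from 25 nM to 200 nM.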

Compound 3, half-maximal inhibitory concentration: > 25000 nM
Compound 3 gave a limit, no number (the forecaster's own chance of this, stated with the estimate: 5%); middle value at least 350-fold (2.55 log units) from the limit.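

The value of compound 3 is a limit of the assay and not a number: the limit of > 25000 nM in this assay, at which 1 of the 3 values shown sits. With the same atoms joined differently, 6-chloro-5-methylpyridazin-3-yl in place of 6-chloro-4-methylpyridazin-3-yl gives an at least 370-fold higher number from compound 2 to compound 3 (2.56 log units; beyond the scatter), a far larger change than the chloro alone gave, a 4.4-fold higher number from compound 1 to compound 2 (0.65 log units; beyond the scatter). Set against the unchlorinated compound, the result is an at least 1600-fold higher number from compound 1 to compound 3 (3.21 log units; beyond the scatter). The placing of the methyl thus matters greatly in this series.

As far as these compounds go, it remains open whether the 5-methyl placement costs as much without the chloro, and whether an ethyl or a methoxy would be tolerated where the methyl sits in compound 2.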